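Working notes: benzoyl to 4-bromobenzyl on the amine nitrogen

This account rests on a few compounds, and the source may have more. Where it says the series, first, only, none or still open, it means among the compounds named here.

- compound 1 `O=C(NO)c1cnc(N2C[C@@H]3[C@H](C2)[C@H]3NC(=O)c2ccc3ccccc3c2)nc1` gives 410 nM
- compound 2 `O=C(NO)c1cnc(N2C[C@@H]3[C@H](C2)[C@H]3NC(=O)c2ccccc2)nc1` gives 5100 nM

In a functional assay on HCT-116 cells (Homo sapiens) for antiproliferative activity, read by WST assay, with a stated time of 72 h (on this read-out higher numbers stand for weaker inhibition of growth and lower numbers for stronger inhibition of growth), compound 2 stands at 5100 nM as the higher of the two numbers. Compound 1 stands at 410 nM. The gap between the two numbers lies beyond the scatter and makes compound 2 the weaker growth inhibitor of the pair.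

Compound 3 `O=C(NO)c1cnc(N2C[C@@H]3[C@H](C2)[C@H]3NCc2ccc(Br)cc2)nc1` is not yet measured. It carries 4-bromobenzyl in place of benzoyl on an amine nitrogen. For the measured compounds named here, no measured pair isolates this change, so the expectation is loose. Going by the values given here, compound 1 at 410 nM shows only that a number well under that of compound 2 can be reached with a different group on this nitrogen. In this assay a fall beyond the scatter is expected, the estimated step being a 5.7-fold lower number from compound 2 to compound 3 (0.75 log units; beyond the scatter) toward stronger inhibition of growth. The estimated value for compound 3 is 900 nM (expected range 200 nM to 4000 nM).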

Compound 3, concentration for 50% growth inhibition: 250 nM
Estimate against measurement, compound 3: 3.6-fold (0.56 log units) above, within the range that was stated.
By their numbers in this assay, from the lowest: compounds 3 and 1 (each within the scatter of the next); then compound 2.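

In this assay, 4-bromobenzyl in place of benzoyl on the amine nitrogen gives a 20-fold lower number from compound 2 to compound 3 (1.31 log units; beyond the scatter), so a group on this nitrogen need not keep the carbonyl for a large fall in the number. Compound 3 at 250 nM and compound 1 at 410 nM lie within the scatter of each other, which shows that both an amide and an amine linkage at this position can reach this level on the shared core. Nothing measured here explains the step.

On these data alone, the step removes the carbonyl and adds the bromine together, so their separate contributions stay open; plain benzyl and 4-bromobenzoyl on this nitrogen would divide them. Also open, as far as these compounds go, is how the number responds to another halogen, as in 4-chlorobenzyl, or to a longer chain, as in 2-phenylethyl.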